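The compounds below may be only part of what the source reports. "The series", "measured", "known", "first", "only" and "open" are said of these compounds alone.

Measured so far:
- compound 1, `CC(C)(C)C(=O)OCC1(CO)C/C(=C\CCCCCCCCCCCO)C(=O)O1`: 5.81 ug/mL
- compound 2, `CC(C)(C)C(=O)OCC1(CO)C/C(=C/CCCCCCCCCCCCCCC=O)C(=O)O1`: > 10 ug/mL

In a functional assay on SK-MEL-5 cells (Homo sapiens) for antiproliferative activity (on this read-out higher numbers stand for weaker inhibition of growth and lower numbers for stronger inhibition of growth), compound 1 gives 5.81 ug/mL, the only number shown for this assay. For compound 2, the same assay reports only a limit, > 10 ug/mL; of the two values shown, one sits at the limit of > 10 ug/mL in this assay, at which 1 of the 2 values shown sits. Among the measured compounds shown here, no step between two measured compounds is available, so the two values can only be set side by side: compound 1 gives a number, compound 2 a limit.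

Compound 3, `CC(C)(C)C(=O)OCCCCCCCCCCCCCCC/C=C1\CC(CO)(COC(=O)C(C)(C)C)OC1=O`, has not yet been tested. It differs from compound 1 in one place: 4-(((tert-butyl)carbonyl)oxy)butyl in place of hydroxy on a saturated chain carbon, ten or more bonds along the chain from a double-bonded chain carbon. The hydroxy at the end of the chain is thus replaced by an ester-bearing extension of the chain.

For the measured compounds named here, with no measured step to lean on, and with compound 2 sitting at a limit, the expectation for compound 3 is loose. It is expected that compound 3 comes out near, or somewhat weaker than, compound 1, with a 1.4-fold higher number from compound 1 to compound 3 (0.14 log units; within the scatter) as the estimated step. The estimate for compound 3 in this assay is 8 ug/mL, with a range from 3 ug/mL to 20 ug/mL.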

Compound 3, concentration for 50% growth inhibition: 3.46 ug/mL
The estimate for compound 3 lay 2.3-fold (0.36 log units) above the measured number, and the stated range covers the measured number.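

In this assay, putting 4-(((tert-butyl)carbonyl)oxy)butyl in place of hydroxy on a saturated chain carbon, ten or more bonds along the chain from a double-bonded chain carbon, gives a 1.7-fold lower number from compound 1 to compound 3 (0.23 log units; within the scatter), so the two compounds cannot be told apart on this read-out. Among the compounds shown here, this place on the chain therefore accepts a much larger group of 11 heavy atoms, and the hydroxy that leaves, with its hydrogen-bond donor, is not needed there for growth inhibition at this level, although the one step cannot separate the added chain length from the ester. Nothing in the data shown bears on why the two compounds read alike.

Going by these compounds, whether an amine or a carboxylic acid at this place would also read like compound 1, and whether a shorter ester-bearing chain would do the same, stays open. Compound 2 gives only a limit, > 10 ug/mL, and it differs from compound 1 in more than one place, so it does not show how far this tolerance extends.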